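From furan-2-yl to 2-hydroxyphenyl: what to expect

A few compounds are considered here, and "the series" means these few. Any claim that something is new, unique, unknown or untested is made for them only; others in the source may bear on it.

Measured so far in a functional assay on HCT-116 cells (Homo sapiens) for inhibition, with a stated time of 72 h; a higher number here means a weaker inhibitor, a lower number a stronger inhibitor:
- compound 1 `NC1CCC(Nc2nc(NCc3ccc(Br)cc3)c3ncn(C4CCCC4)c3n2)CC1`: 790 nM
- compound 2 `NC1CCC(Nc2nc(NCc3ccc(-c4ccco4)nc3)c3ncn(C4CCCC4)c3n2)CC1`: 86 nM
- compound 3 `OC1CCC(Nc2nc(NCc3ccc(-c4ccco4)nc3)c3ncn(C4CCCC4)c3n2)CC1`: 617 nM

Compound 2, at 86 nM, has the lowest number of the three, which makes it the strongest inhibitor measured here. The next compound to consider is compound 4 `NC1CCC(Nc2nc(NCc3ccc(-c4ccccc4O)nc3)c3ncn(C4CCCC4)c3n2)CC1`, which differs from compound 2 in one group: 2-hydroxyphenyl in place of furan-2-yl on an aromatic carbon. Put simply, 2-hydroxyphenyl stands in place of furan-2-yl on an aromatic carbon, next to the ring nitrogen.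

For the measured compounds named here, two measured steps bear on this change. The closer one is a 9.2-fold lower number from compound 1 to compound 2 (0.96 log units; beyond the scatter), where 6-(furan-2-yl)pyridin-3-yl replaced 4-bromophenyl, so the end of the molecule that changes in compound 4 was altered there too. The other is a 7.2-fold higher number from compound 2 to compound 3 (0.86 log units; beyond the scatter), where hydroxy replaced amino on a saturated ring carbon, elsewhere in the molecule. Both steps were modest, and neither tested this particular swap, so the direction remains uncertain. Starting from the lowest number in the set, a small rise is more likely than a further fall. The expected change is a 2.3-fold higher number from compound 2 to compound 4 (0.37 log units; beyond the scatter). For compound 4 the estimated value is 200 nM, with an expected range from 60 nM to 650 nM.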

Compound 4, half-maximal inhibitory concentration: 35 nM
Compound 4: the middle estimate sits 5.7-fold (0.76 log units) above what was measured; measured number below the stated range.
By their numbers in this assay, from the lowest: compound 4; then compound 2; then compounds 3 and 1 (each within the scatter of the next).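

In this assay, for the compounds shown here, replacing furan-2-yl with 2-hydroxyphenyl gives a 2.5-fold lower number from compound 2 to compound 4 (0.39 log units; beyond the scatter), so the lowest number among the earlier compounds was not the limit for this position, on an aromatic carbon next to the ring nitrogen. The earlier change at this end of the molecule swapped the whole 4-bromophenyl group for 6-(furan-2-yl)pyridin-3-yl, whereas this one keeps the ring bearing the group and alters only the group itself, showing that this group alone moves the number beyond the scatter. The position accepts a larger six-membered ring of carbon only, carrying a hydrogen-bond donor where furan-2-yl has none, although nothing shown here explains why the number falls.

As far as these compounds go, the change alters the ring and adds the hydroxy group in one step, so the effect of each remains open; plain phenyl, 2-methoxyphenyl and 2-aminophenyl at this position would help to separate them. Also open, from the compounds shown here alone, is whether the amino group on the saturated ring matters as much alongside 2-hydroxyphenyl, since a 7.2-fold higher number from compound 2 to compound 3 (0.86 log units; beyond the scatter) was seen with furan-2-yl in place.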